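From carboxy to carboxymethyl on a saturated ring carbon

This account rests on a few compounds, and the source may have more. Where it says the series, first, only, none or still open, it means among the compounds named here.

Values so far in an ADME assay on the whole organism (Rattus norvegicus) for pharmacokinetics, at a dose of 1 mg/kg by the oral route (a lower number here means that a smaller share of the oral dose reaches the circulation, a higher number that a larger share of the oral dose reaches the circulation), for two compounds
Compound 1 `COc1ccc(F)cc1-c1ccnc2[nH]c(C3=CCN([C@H]4CC[C@H](C(=O)O)CC4)CC3)cc12` gives 23%
Compound 2 `COc1ccc(F)cc1-c1c(F)cnc2[nH]c(C3=CCN([C@H]4CC[C@H](C(=O)O)CC4)CC3)cc12` gives 28%

Compound 2 at 28% cannot be told apart from compound 1 at 23% on these numbers. Going by the values given here, the only measured step is a number 5 percentage points higher from compound 1 to compound 2 (within the scatter) and it is fluoro in place of hydrogen on an aromatic carbon, so it leaves the carboxy group untouched.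

The next compound is compound 3 `COc1ccc(F)cc1-c1c(F)cnc2[nH]c(C3=CCN([C@H]4CC[C@H](CC(=O)O)CC4)CC3)cc12` and its difference from compound 2 is carboxymethyl in place of carboxy on a saturated ring carbon in full. In words, it is carboxymethyl in place of carboxy on a saturated ring carbon. Among the compounds with values here, no measured step covers a change of this kind, and the data therefore give no direction for it. Starting from compound 2 at 28% as the nearest reference, no step beyond the scatter is expected in this assay for this change. The expected step is a number 1 percentage points lower from compound 2 to compound 3 (within the scatter) and this remains only an estimate. Compound 3 is estimated at 27% with an expected range from 10% to 50% in this measurement.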

Compound 3, oral bioavailability: 11%
Compound 3: the middle estimate sits 16 percentage points above what was measured, and the stated range covers the measured number.
By their numbers in this assay, from the lowest: compound 3; then compounds 1 and 2 (each within the scatter of the next).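

In this assay, this position on the saturated ring carbon proves sensitive to a small change: a number 17 percentage points lower from compound 2 to compound 3 (beyond the scatter). Going by these compounds alone, the only other measured step, between compound 1 and compound 2, left the carboxy group in place. The carboxylic acid itself remains, and the computed counts of hydrogen-bond donors, hydrogen-bond acceptors and net charge stay as they were, so the step from 4-carboxycyclohexyl to 4-(carboxymethyl)cyclohexyl is not accompanied by a change in any of these counts. No available measurement bears on why the oral bioavailability fell.

The compounds shown leave open whether a longer chain carrying the carboxylic acid would continue in the same direction, and whether the step would be the same without the fluoro group that compound 2 and compound 3 share. They also leave open how an amide, a tetrazole or an amine on the same saturated ring carbon would stand in this assay.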